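A few compounds are considered here, and "the series" means these few. Any claim that something is new, unique, unknown or untested is made for them only; others in the source may bear on it.

Series notes. Compound 1 `O=C(COc1ccc(Oc2ccccc2)cc1)Cn1ncc2cc(C(=O)O)ccc21` carries a carboxy on an aromatic carbon of the shared core; in an assay on microsomes from brain for inhibition of Fatty-acid amide hydrolase 1 (Rattus norvegicus), read by fluorescence and HPLC, with a stated time of 45 min (a lower number here means a stronger inhibitor, a higher number a weaker inhibitor), compound 1 gives 55 nM. Compound 2 `O=C(COc1ccc(Oc2ccccc2)cc1)Cn1ncc2ccccc21` has hydrogen on that aromatic carbon, and compound 2 gives 2600 nM. Compound 3 `COCC(=O)Nc1ccc2c(cnn2CC(=O)COc2ccc(Oc3ccccc3)cc2)c1` carries a ((methoxymethyl)carbonyl)amino group on the same aromatic carbon, and compound 3 gives 6300 nM. The steps read a 47-fold higher number from compound 1 to compound 2 (1.67 log units; beyond the scatter) and a 110-fold higher number from compound 1 to compound 3 (2.06 log units; beyond the scatter), both large, while a 2.4-fold higher number from compound 2 to compound 3 (0.38 log units; beyond the scatter) is modest. Compound 3 thus stands highest of the three numbers, nearest to compound 2 and furthest from compound 1.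

Compound 4 `O=C(COc1ccc(Oc2ccccc2)cc1)Cn1ncc2cc(NC(=O)CO)ccc21` differs from compound 3 by hydrogen in place of methyl on an oxygen on a saturated carbon, on an oxygen on a saturated carbon whose other neighbour is a saturated chain carbon; cut one bond further out this reads methoxy to hydroxy, or (methoxymethyl)carbonyl to (hydroxymethyl)carbonyl. None of the three measured steps touches this oxygen; all three exchange the group on the aromatic carbon. The guidance is therefore indirect: a change inside the acylamino group is expected to move this assay little because a 2.4-fold higher number from compound 2 to compound 3 (0.38 log units; beyond the scatter) is itself only modest for the whole group. The expected step of a 1.3-fold lower number from compound 3 to compound 4 (0.10 log units; within the scatter) is small, in no firm direction, and likely within scatter. Compound 4 is estimated at 5000 nM, range 1800 nM to 14000 nM.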

Compound 4, half-maximal inhibitory concentration: 5400 nM
For compound 4 the middle estimate is 1.1-fold (0.03 log units) below the measured one; low and high end bracket the measured number.
By their numbers in this assay, from the lowest: compound 1; then compound 2; then compounds 4 and 3 (each within the scatter of the next).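

In this assay, the exchange of methoxy for hydroxy inside the acylamino group gives a 1.2-fold lower number from compound 3 to compound 4 (0.07 log units; within the scatter) and so leaves no readable effect of the methyl on this oxygen. The ((hydroxymethyl)carbonyl)amino group, set against the other two groups on the aromatic carbon, gives a 2.1-fold higher number from compound 2 to compound 4 (0.32 log units; beyond the scatter) against hydrogen, a modest step, and a 98-fold higher number from compound 1 to compound 4 (1.99 log units; beyond the scatter) against carboxy, a large one, so compound 4 stands as far from compound 1 as compound 3 does, and neither acylamino compound recovers the low number of compound 1. No measurement at hand explains any of these steps.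

Still open, as far as these compounds go, is whether a carboxymethyl group, a sulfonic acid or a tetrazole on this aromatic carbon would stay near compound 1 or fall back towards the acylamino compounds. Also open, from the compounds shown here alone, is whether an amine or a longer chain on the acyl carbonyl, or a carboxylic acid at the end of such a chain, would move the number away from the level shared by compound 3 and compound 4.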